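Uracil alkynes with a phthalimide-bearing butenyl chain

The compounds below may be only part of what the source reports. "The series", "measured", "known", "first", "only" and "open" are said of these compounds alone.

Of the compounds shown here, two have been tested for their effect on the growth of liver cancer cells. In a functional assay on HepG2 cells (Homo sapiens) for antiproliferative activity, read by MTT assay, with a stated time of 3 days (on this read-out lower numbers stand for stronger inhibition and higher numbers for weaker inhibition), compound 1 `O=C1c2ccccc2C(=O)N1C/C=C\Cn1cc(C#Cc2ccc(Br)cc2)c(=O)[nH]c1=O` gives 89000 nM. Compound 2 `CCCCCCC#Cc1cn(C/C=C/CN2C(=O)c3ccccc3C2=O)c(=O)[nH]c1=O` carries a straight hexyl chain on its triple bond instead of a bromophenyl group, and also differs in the geometry of the linking chain; in this assay compound 2 gives 14000 nM, the lower of the two numbers and therefore the stronger inhibitor, with compound 1 standing well beyond the usual scatter above it. Compound 3 `CCCCc1ccc(C#Cc2cn(C/C=C/CN3C(=O)c4ccccc4C3=O)c(=O)[nH]c2=O)cc1` has not yet been tested. It keeps the whole of compound 2 except for one change: 4-butylphenyl in place of hexyl on a triple-bonded carbon. For the measured compounds named here, no measured pair shows exactly this change. Compound 1 suggests that an aromatic group on the triple bond may weaken the effect, but its chain geometry also differs, so the comparison is uncertain. A moderate loss is expected, so that compound 3 is estimated at 25000 nM in this assay, between 8000 nM and 80000 nM, a step of a 1.8-fold higher number from compound 2 to compound 3 (0.25 log units; within the scatter).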

Compound 3, half-maximal inhibitory concentration: 9100 nM
Compound 3: middle estimate off by 2.7-fold (0.44 log units), on the high side; the measured number falls inside the stated range.
By their numbers in this assay, from the lowest: compounds 3 and 2 (each within the scatter of the next); then compound 1.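

Compound 2 and compound 3 are the first pair shown that differ in this one place alone. In this assay, 4-butylphenyl in place of hexyl on a triple-bonded carbon gives a 1.5-fold lower number from compound 2 to compound 3 (0.19 log units; within the scatter), so the two compounds cannot be told apart, and this position carries either a straight chain or a six-membered aromatic ring with no measurable change in the number. Nothing in the available data explains why these two groups give such similar results.

Going by these compounds, it remains open whether an unsubstituted phenyl, a longer chain, or a group ending in an amine or a carboxylic acid would give a number of similar size at this position. The effect of the geometry of the linking chain also remains open, as no two compounds shown differ in that alone.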